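Adding a Methoxy Group to a Set Without Measurable Potency

This account rests on a few compounds, and the source may have more. Where it says the series, first, only, none or still open, it means among the compounds named here.

Compound 1 `Cc1nc(SCC(=O)Nc2nc(-c3ccc(Cl)cc3)cs2)n(Nc2ccccc2)c1C` was examined in a functional assay on OVCAR-4 cells (Homo sapiens) for antiproliferative activity, read by sulforhodamine B assay, with a stated time of 48 h; a higher number here means that more compound is tolerated, a lower number that less compound is tolerated. In this assay compound 1 gives only a limit, > 100000 nM, and not a number. A second member of the set, compound 2 `Cc1ccc(Nn2c(SCC(=O)Nc3nc(-c4ccccc4)cs3)nc(C)c2C)cc1`, differs from compound 1 in more than one place. In this assay compound 2 likewise reaches only a limit, > 100000 nM. Compound 1 therefore stands where every shown value stands: the limit of > 100000 nM in this assay, at which 2 of the 2 values shown sit, so no order among the measured compounds can be read and no step between them can be sized.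

Compound 3 `COc1ccc(Nn2c(SCC(=O)Nc3nc(-c4ccc(Cl)cc4)cs3)nc(C)c2C)cc1` has not yet been measured. It differs from compound 1 by a single change: methoxy in place of hydrogen on an aromatic carbon. Among the compounds with values here, no measured step exists to gauge this change, and no property of the methoxy group has been measured here. Because both shown values sit at the limit of > 100000 nM in this assay, at which 2 of the 2 values shown sit, no departure beyond the scatter is expected from this step. The expected step from compound 1 to compound 3 is a step that the limit leaves unreadable from compound 1 to compound 3, that is, none beyond the scatter. Compound 3 is estimated at 150000 nM, within a range from 50000 nM to 500000 nM, most likely again reported only as a limit.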

Compound 3, concentration lethal to 50% of the cells: > 100000 nM
Compound 3: only a limit was reported; the forecaster's own chance of this, stated with the estimate: 80%; the middle value is on the limit's open side.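

In this assay compound 3 gives > 100000 nM, a limit and not a number, so no step can be read between compound 1 and compound 3: the limit of > 100000 nM in this assay, at which 3 of the 3 values shown sit.

The compounds shown leave open whether methoxy in place of hydrogen on an aromatic carbon shifts the response in this assay, and what actual number any of these compounds would reach.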